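Same atoms, rearranged side chain: compound 3 awaits measurement

A few compounds are considered here, and "the series" means these few. Any claim that something is new, unique, unknown or untested is made for them only; others in the source may bear on it.

Measured so far in an ADME assay on microsomes from liver (Rattus norvegicus) for metabolic stability, read by mass spectrometry, using NADPH, with a stated time of 10 min; a higher number here means that more of the compound is left, a lower number that less of the compound is left:
Compound 1 `COc1cccc(OC)c1-c1c(C2CCCC2)[nH]c(=O)c(-c2nnc(Cc3ccc(Cl)cc3)o2)c1O` gives 66%
Compound 2 `CCOCc1[nH]c(=O)c(-c2nnc(Cc3ccc(Cl)cc3)o2)c(O)c1-c1c(OC)cccc1OC` gives 74%

Among the measured compounds shown here, compound 2 stands level with compound 1, the only other measured compound, since the two values lie within the usual scatter. Compound 3 `COCCc1[nH]c(=O)c(-c2nnc(Cc3ccc(Cl)cc3)o2)c(O)c1-c1c(OC)cccc1OC` has the same atoms as compound 2, joined differently (methoxymethyl in place of ethoxy on a saturated chain carbon bound to an aromatic carbon), so that ethoxymethyl becomes 2-methoxyethyl. For the measured compounds named here, the one measured step that bears on this, a number 8 percentage points higher from compound 1 to compound 2 (within the scatter), placed ethoxymethyl where cyclopentyl stood and stayed within the scatter. No shift beyond the scatter is therefore expected in this assay. The estimated step is a number 4 percentage points lower from compound 2 to compound 3 (within the scatter), which is no real change. Compound 3 is expected at 70%, with an estimated range from 56% to 83%.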

Compound 3, percent of the compound remaining: 73%
Compound 3: the middle estimate sits 3 percentage points below what was measured; the range from low to high includes it.
By their numbers in this assay, from the lowest: compounds 1, 3 and 2 (each within the scatter of the next).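

In this assay, turning ethoxymethyl into 2-methoxyethyl gives a number 1 percentage points lower from compound 2 to compound 3 (within the scatter) and shows that rearranging these same atoms on the saturated chain leaves the read-out level. Swapping cyclopentyl for 2-methoxyethyl gives a number 7 percentage points higher from compound 1 to compound 3 (within the scatter) and so adds a second ether chain that stands level with cyclopentyl. No accompanying measurement offers an explanation for these results.

From the compounds shown here alone, whether an amine, a carboxylic acid or a longer chain at this position would also stay level in this assay remains open.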